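Trimethoxyphenyl in Place of Methoxyphenyl: An Expected Value

The compounds below may be only part of what the source reports. "The series", "measured", "known", "first", "only" and "open" are said of these compounds alone.

Measured compounds:
compound 1: `COc1cc(/C=C/C(=O)c2cccc(-n3cc(-c4ccccc4)[nH]c3=O)c2)cc(OC)c1OC` gives 1930 nM
compound 2: `COc1ccc(-c2cn(-c3cccc(C(=O)/C=C/c4cc(OC)c(OC)c(OC)c4)c3)c(=O)[nH]2)cc1` gives 2590 nM

Both compounds were tested in a functional assay on BT-549 cells (Homo sapiens) for inhibition; on this read-out lower numbers stand for stronger inhibition of growth and higher numbers for weaker inhibition of growth. Among the measured compounds shown here, compound 2 stands highest of the two numbers, yet its only neighbor is compound 1, and the step of a 1.3-fold higher number from compound 1 to compound 2 (0.13 log units; within the scatter) lies within the scatter, so the two values cannot be placed in order. That step is the single measured one, and it exchanges hydrogen for methoxy on an aromatic carbon of the phenyl group that sits on the five-membered ring.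

Compound 3 is `COc1cc(/C=C/C(=O)c2cccc(-n3cc(-c4cc(OC)c(OC)c(OC)c4)[nH]c3=O)c2)cc(OC)c1OC`. It differs from compound 2 in one place: 3,4,5-trimethoxyphenyl in place of 4-methoxyphenyl on an aromatic carbon. The step already measured bears directly on this change, since it added the first methoxy to the same phenyl group and moved this assay by no more than the scatter. Two further methoxy groups on that ring are therefore expected to leave the number near its present place, perhaps drifting a little higher but not beyond the scatter. The expected step is a 1.2-fold higher number from compound 2 to compound 3 (0.09 log units; within the scatter). Compound 3 is estimated to give 3200 nM, within a range from 1500 nM to 7000 nM.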

Compound 3, concentration for 50% growth inhibition: 1520 nM
Estimate against measurement, compound 3: 2.1-fold (0.32 log units) above, within the range that was stated.
By their numbers in this assay, from the lowest: compounds 3, 1 and 2 (each within the scatter of the next).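

In this assay this position on the five-membered aromatic ring with 2 nitrogen has now carried three different aryl groups, and none of the steps between them leaves the scatter. Replacing 4-methoxyphenyl with 3,4,5-trimethoxyphenyl gives a 1.7-fold lower number from compound 2 to compound 3 (0.23 log units; within the scatter) and so adds no measurable shift, while the wider exchange of phenyl for 3,4,5-trimethoxyphenyl gives a 1.3-fold lower number from compound 1 to compound 3 (0.10 log units; within the scatter) and shows that even the full change, which the earlier single step could not show, stays within the scatter; the entering group, with 12 heavy atoms and 3 hydrogen-bond acceptors against 8 heavy atoms and 1 hydrogen-bond acceptor for 4-methoxyphenyl, therefore leaves the read-out where it was. Nothing measured here offers an explanation for this flat picture.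

What the compounds shown leave open is whether it holds for groups other than methoxy on that phenyl, such as a hydroxyl, an amine or a carboxylic acid. They also leave open whether a longer chain standing in place of the whole aryl group on this ring carbon would stay within the scatter of these values.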